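The source may hold more compounds than are shown below. What is called first, only, known or untested is meant among the compounds shown, and "the series" means these compounds.

In a functional assay on HCT-116 cells (Homo sapiens) for antiproliferative activity, read by MTT assay, with a stated time of 72 h (a higher number here means a weaker inhibitor, a lower number a stronger inhibitor), compound 1 (`COc1cc(OC)cc(-c2cccc(NC(=O)CCc3cccc4c3B(O)OC4)c2)c1`) gives 53 nM, while compound 2 (`COc1cccc(-c2cccc(NC(=O)CCc3ccc4c(c3)COB4O)c2)c1`) gives 81000 nM, the higher of the two numbers and far beyond the scatter. Compound 3 (`COc1cc(OC)cc(-c2cccc(NC(=O)CCc3ccc4c(c3)COB4O)c2)c1`) differs from compound 2 by methoxy in place of hydrogen on an aromatic carbon, turning 3-methoxyphenyl into 3,5-dimethoxyphenyl. Going by the values given here, no measured pair shows this change alone. The 3,5-dimethoxyphenyl group also occurs in compound 1, at 53 nM, which points toward a lower number. The expected change is a 10-fold lower number from compound 2 to compound 3 (1.01 log units; beyond the scatter), beyond the scatter, toward a stronger inhibitor. For compound 3 the estimated value is 8000 nM, with an expected range from 500 nM to 100000 nM.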

Compound 3, half-maximal inhibitory concentration: 56000 nM
Compound 3: the middle estimate sits 7.0-fold (0.85 log units) below what was measured; measured number inside the range.
By their numbers in this assay, from the lowest: compound 1; then compounds 3 and 2 (each within the scatter of the next).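

In this assay, the step from 3-methoxyphenyl to 3,5-dimethoxyphenyl reads a 1.4-fold lower number from compound 2 to compound 3 (0.16 log units; within the scatter), so on this core the added methoxy does not close the distance to compound 1. With 3,5-dimethoxyphenyl present in both compounds, the step of a 1100-fold higher number from compound 1 to compound 3 (3.02 log units; beyond the scatter) places the large gap in the boron-containing group at the end of the chain, which has the same atom count in both. Nothing measured here bears on why that group matters so much.

On these data alone, how an amine or a carboxylic acid would fare in place of that methoxy remains open. So does whether a longer chain would alter the gap.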